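The compounds below may be only part of what the source reports. "The series", "measured", "known", "first", "only" and "open" are said of these compounds alone.

Compound 1 `Cc1ccncc1OC[C@@H]1CCCN1C` reaches 73.9% in an assay on K177 cells with Neuronal acetylcholine receptor; alpha4/beta2 (Homo sapiens) as the target; on this read-out higher numbers stand for larger maximal responses and lower numbers for smaller maximal responses. Among the measured compounds shown here, compound 2 `CN1CCC[C@H]1COc1cnccc1Br` gives only 14.1% in this assay, and the single change between them, (methyl in place of bromo on an aromatic carbon), produced a step of a number 59.8 percentage points higher from compound 2 to compound 1 (beyond the scatter). Compound 3 `CN1CCC[C@H]1COc1cncc(Br)c1` stands in this assay at 41.8%; it has the same atoms as compound 2 joined differently, and the difference between the two cores is not broken down here. Compound 4 `Cc1cncc(OC[C@@H]2CCCN2C)c1` is not yet measured. Its change from compound 3 is methyl in place of bromo on an aromatic carbon, the same kind of change as from compound 2 to compound 1, but at a place that is two atoms from the ring nitrogen and meta to a group of 8 heavy atoms rather than ortho to that group and opposite the ring nitrogen. Because the earlier step was a number 59.8 percentage points higher from compound 2 to compound 1 (beyond the scatter), the step from compound 3 to compound 4 is expected to be a number 30.2 percentage points higher from compound 3 to compound 4 (beyond the scatter). Compound 4 is therefore estimated at 72%, expected between 50% and 92%.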

Compound 4, largest response reached (reported as maximum), in percent of the reference or control that the assay uses: 77%
Compound 4: middle estimate off by 5 percentage points, on the low side, and the stated range covers the measured number.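

In this assay, methyl in place of bromo on the core of compound 3 gave a number 35.2 percentage points higher from compound 3 to compound 4 (beyond the scatter), the same direction as on the core of compound 1. The direction of the change therefore carried over between the two cores, but its size did not: the same change on two cores in this assay, a number 59.8 percentage points higher (beyond the scatter) from compound 2 to compound 1 and a number 35.2 percentage points higher (beyond the scatter) from compound 3 to compound 4, 24.6 percentage points apart, beyond the scatter of two such steps

Among the compounds shown here, with only two pairs, this does not explain why the steps differ in size, and it gives no rule for how large the step would be on any further core. The compounds shown leave open what other groups would do at these places, such as chloro, methoxy or an amine. On these data alone, whether a longer chain such as ethyl would behave like methyl also remains open.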